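Inverting Both Stereocentres of Compound 1

This account rests on a few compounds, and the source may have more. Where it says the series, first, only, none or still open, it means among the compounds named here.

Compound 1 `C[C@H](C(=O)NC[C@H](COC(=O)C(C)(C)C)Cc1ccccc1)c1ccc(NS(C)(=O)=O)c(F)c1` gives 43 nM in an assay on CHO cells for displacement of a labelled ligand from transient receptor potential cation channel subfamily V member 1 (Rattus norvegicus); a higher number here means a weaker inhibitor, a lower number a stronger inhibitor.
Compound 2 `C[C@@H](C(=O)NC[C@H](COC(=O)C(C)(C)C)Cc1ccccc1)c1ccc(NS(C)(=O)=O)c(F)c1` gives 298 nM in this assay.
Compound 3 `COc1cc(C(C)(C)C(=O)NCC(COC(=O)C(C)(C)C)Cc2ccc(C)c(C)c2)ccc1NS(C)(=O)=O` gives 153 nM in this assay.

Compound 1 stands lowest of the three numbers measured in this assay; the nearest to it is compound 3, and the furthest is compound 2. The step under consideration leads from compound 1 to compound 4 `C[C@@H](C(=O)NC[C@@H](COC(=O)C(C)(C)C)Cc1ccccc1)c1ccc(NS(C)(=O)=O)c(F)c1`, and it changes no atom or bond: the two compounds have the same atoms and bonds and differ only in configuration as drawn: 2 of 2 stereo elements differ (all stereocentres are inverted: mirror images); a stereocentre at a saturated chain carbon is drawn S in compound 1 and R in compound 4; a stereocentre at a saturated chain carbon is drawn R in compound 1 and S in compound 4.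

Within the data shown here, only one measured step bears on this change. Inverting a single stereocentre gave a 6.9-fold higher number from compound 1 to compound 2 (0.84 log units; beyond the scatter), a change attributable to the fact that compounds 1 and 2 differ only in the configuration as drawn. Compound 4 inverts both centres rather than one, so the comparison is not exact, but the precedent points towards a weaker inhibitor. A step in the same direction as that from compound 1 to compound 2, and at least as large, is therefore expected in this assay.

For compound 4 the estimate is 400 nM, with a range from 100 nM to 1600 nM, corresponding to an expected step of a 9.3-fold higher number from compound 1 to compound 4 (0.97 log units; beyond the scatter).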

Compound 4, inhibition constant: 370 nM
The estimate for compound 4 lay 1.1-fold (0.03 log units) above the measured number; low and high end bracket the measured number.
By their numbers in this assay, from the lowest: compound 1; then compounds 3, 2 and 4 (each within the scatter of the next, the first and the last beyond it).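

Taken with the mirror-image pair, an 8.6-fold higher number from compound 1 to compound 4 (0.93 log units; beyond the scatter) shows that the preference for compound 1 in this assay survives when both stereocentres are inverted, and the step is of much the same size as the single inversion, a 6.9-fold higher number from compound 1 to compound 2 (0.84 log units; beyond the scatter). The new information lies in the second inversion, which gives a 1.2-fold higher number from compound 2 to compound 4 (0.09 log units; within the scatter), so the two compounds it links cannot be told apart. Once the first centre has been inverted, therefore, the configuration at the remaining centre makes no difference that can be read in this series.

Whether that remaining centre matters in the configuration of compound 1 stays open, as the compounds shown do not isolate its inversion there. On these data alone, it is also open whether the same preference would hold with an amine or a carboxylic acid in place of the ester.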